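Ethylation of a Naphthylguanidine Nitrogen: Predicting Compound 4

This account rests on a few compounds, and the source may have more. Where it says the series, first, only, none or still open, it means among the compounds named here.

Measured compounds:
compound 1, `N=C(Nc1cccc2ccccc12)Nc1cccc2ccccc12`, 165 nM in an assay on membranes from brain (Cavia porcellus) for binding affinity to Sigma non-opioid intracellular receptor 1 (Homo sapiens), read by radioligand binding; on this read-out higher numbers stand for weaker inhibition and lower numbers for stronger inhibition
compound 2, `CCN(C(=N)Nc1cccc2ccccc12)c1cccc2ccccc12`, 6130 nM in this assay
compound 3, `CCc1cccc(NC(=N)Nc2cccc3ccccc23)c1`, 54 nM in this assay

Compound 3 has the lowest number of the three measured compounds in this assay. The difference between the core of compound 3 and the core of compound 1 is not broken down here. Compound 4, `CCc1cccc(N(CC)C(=N)Nc2cccc3ccccc23)c1`, is not yet measured; it differs from compound 3 by ethyl in place of hydrogen on a nitrogen on an aromatic ring. The same change is seen once among the measured compounds, where compound 2 differs from compound 1 by ethyl in place of hydrogen on a nitrogen on an aromatic ring, and that step gave a 37-fold higher number from compound 1 to compound 2 (1.57 log units; beyond the scatter). Because the earlier step was a 37-fold higher number from compound 1 to compound 2 (1.57 log units; beyond the scatter), a step of about a 37-fold higher number from compound 3 to compound 4 (1.57 log units; beyond the scatter) is expected for compound 4. Compound 4 is therefore estimated at 2000 nM, with a likely range from 500 nM to 8000 nM.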

Compound 4, half-maximal inhibitory concentration: 2190 nM
The estimate for compound 4 lay 1.1-fold (0.04 log units) below the measured number; low and high end bracket the measured number.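

Ethyl in place of hydrogen on a nitrogen on an aromatic ring gave a 41-fold higher number from compound 3 to compound 4 (1.61 log units; beyond the scatter) in this assay. Set beside the earlier step, the change carried over from one core to the other at much the same size: the same change on two cores in this assay, a 37-fold higher number (1.57 log units; beyond the scatter) from compound 1 to compound 2 and a 41-fold higher number (1.61 log units; beyond the scatter) from compound 3 to compound 4, 1.1-fold (0.04 log units) apart, within the scatter of two such steps. This shows agreement on two cores only; it does not show that the step would hold on any other core in the series, nor does it explain why the number rises.

The compounds shown leave open whether methyl or a longer chain such as propyl on this nitrogen would give a step of similar size. They also leave open whether a core bearing an amine or a carboxylic acid would respond in the same way.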